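A few compounds are considered here, and "the series" means these few. Any claim that something is new, unique, unknown or untested is made for them only; others in the source may bear on it.

Compound 1 `Cc1cc(C)c(-c2nc(CN3CCC(C(=O)NCCCN4C[C@H](C)C[C@H](C)C4)CC3)c(C)o2)c(C)c1` gives > 0.5 h in an ADME assay on microsomes from liver (Rattus norvegicus) for metabolic stability, read by LC-MS, using NADPH, at 37 degrees C (on this read-out lower numbers stand for a shorter-lived compound and higher numbers for a longer-lived compound), a limit of the assay. Compound 2 `Cc1ccccc1-c1nc(CN2CCC(C(=O)NCCCN3CCCCC3)CC2)c(C)o1` gives > 0.5 h, also a limit of the assay. Compound 3 `Cc1ccccc1-c1nc(CN2CCC(C(=O)NCCCCN3C[C@H](C)C[C@H](C)C3)CC2)c(C)o1` gives 0.2 h.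

Compound 1 therefore stands at the limit, as described by the limit of > 0.5 h in this assay, at which 2 of the 3 values shown sit, and no number for it is known. Among the compounds with values here, the only measured step, an at least 2.5-fold lower number from compound 2 to compound 3 (0.39 log units; beyond the scatter), concerns the chain and not the aryl group, so it does not bear on the change at hand. Compound 4 `COc1cccc(OC)c1-c1nc(CN2CCC(C(=O)NCCCN3C[C@H](C)C[C@H](C)C3)CC2)c(C)o1` differs from compound 1 by 2,6-dimethoxyphenyl in place of 2,4,6-trimethylphenyl on an aromatic carbon. Within the data shown here, no measured step touches that position, so the step of a number no higher from compound 1 to compound 4 (the limit leaves the size open) is expected to stay within the scatter. Compound 4 is therefore estimated at 0.5 h, in the range of 0.2 h to 1 h.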

Compound 4, half-life: 0.2 h
Beside the measured number, compound 4's estimate is 2.5-fold (0.40 log units) above it; low and high end bracket the measured number.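

In this assay the exchange of 2,4,6-trimethylphenyl for 2,6-dimethoxyphenyl gives an at least 2.5-fold lower number from compound 1 to compound 4 (0.39 log units; beyond the scatter). This shows that the half-life responds to the aryl group at this place, which the earlier step, confined to the chain, could not show. As far as these compounds go, the full size of the drop stays open, since compound 1 rests at a limit of the assay: the limit of > 0.5 h in this assay, at which 2 of the 4 values shown sit. From the compounds shown here alone, whether a 2,6-dimethylphenyl group would match compound 1 or compound 4 remains open. So does the effect of a pyridine ring at this place.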